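The compounds below may be only part of what the source reports. "The series", "measured", "known", "first", "only" and "open" are said of these compounds alone.

Measured compounds:
- compound 1 `CC(=O)N1CCC(n2c(-c3ccc(OCc4c(-c5c(Cl)cccc5Cl)noc4C(C)C)cc3)nc3ccc(C(=O)O)cc32)CC1`: "not determined" (no result reported) in an assay on isolated protein for agonist activity at Bile acid receptor (Homo sapiens), read by TR-FRET; a lower number here means that less compound is needed, a higher number that more compound is needed for the effect
- compound 2 `CCC(CC)n1c(-c2ccc(OCc3c(-c4c(Cl)cccc4Cl)noc3C(C)C)cc2Cl)nc2ccc(C(=O)O)cc21`: 21.6 nM

For the measured compounds named here, compound 1 stands on no number in this assay; the only measured value belongs to compound 2, which in this assay gives 21.6 nM. Compound 3 `CCCn1c(-c2ccc(OCc3c(-c4c(Cl)cccc4Cl)noc3C(C)C)cc2)nc2ccc(C(=O)O)cc21` is the unmeasured member. It differs from compound 1 in one place: propyl in place of 1-acetylpiperidin-4-yl on an aromatic nitrogen. Going by the values given here, with no value for compound 1, no step can be stated for this change and neither its size nor its direction follows from the series; the sole anchor is compound 2, which carries a different chain on the same ring nitrogen and an additional chlorine on the phenyl ring, and is therefore not a one-place comparison. Compound 3 is expected to land in the same broad potency region as compound 2, with wide uncertainty, at an estimated 60 nM, within a range of 15 nM to 250 nM.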

Compound 3, half-maximal effective concentration: 96.4 nM
Compound 3: middle estimate off by 1.6-fold (0.21 log units), on the low side; measured number inside the range.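

In this assay, for the compounds shown here, compound 1 gives "not determined" (no result reported), so no step from compound 1 to compound 3 can be read. The compounds shown leave open how far, and in which direction, propyl in place of 1-acetylpiperidin-4-yl shifts the value. No evidence at hand bears on this result.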